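The source may hold more compounds than are shown below. What is called first, only, known or untested is meant among the compounds shown, and "the series" means these compounds.

Measured so far in a functional assay on HepG2 cells (Homo sapiens) for cytotoxicity, read by MTT assay; on this read-out higher numbers stand for weaker inhibition and lower numbers for stronger inhibition:
- compound 1 `C=C1C(=O)[C@]23C[C@@]1(Cl)CC[C@H]2[C@@]12C=CC(=O)[C@](C)(C(=O)O1)[C@H]2[C@@H]3C(=O)OC`: 39800 nM
- compound 2 `C=C1C(=O)[C@]23C[C@@]1(Cl)CC[C@H]2[C@@]12C=CC(=O)[C@](C)(C(=O)O1)[C@H]2[C@@H]3C(=O)OCc1ccccc1`: 17900 nM
- compound 3 `C=C1C(=O)[C@]23C[C@@]1(O)CC[C@H]2[C@@]12C=CC(=O)[C@](C)(C(=O)O1)[C@H]2[C@@H]3C(=O)OC`: 37200 nM

Compound 3, at 37200 nM, sits level with compound 1 within the scatter, as the step of a 1.1-fold lower number from compound 1 to compound 3 (0.03 log units; within the scatter) shows, so hydroxy in place of chloro on a saturated ring carbon leaves the number effectively unchanged. For the measured compounds named here, compound 2 gives a lower number than either of them, and only this compound stands apart from the other two.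

The next compound is compound 4 `C=C1C(=O)[C@]23C[C@@]1(O)CC[C@H]2[C@@]12C=CC(=O)[C@](C)(C(=O)O1)[C@H]2[C@@H]3C(=O)OCc1ccccc1`. It keeps the hydroxy group of compound 3 and differs from it by phenyl in place of hydrogen on a saturated chain carbon bound to an oxygen next to a carbonyl group. In words, this is phenyl in place of hydrogen on a saturated chain carbon bound to an oxygen next to a carbonyl group, or methoxycarbonyl to benzyloxycarbonyl.

Going by the values given here, one measured step bears directly on this change: a 2.2-fold lower number from compound 1 to compound 2 (0.35 log units; beyond the scatter), a modest step made on the chloro compounds. As far as these compounds go, whether it carries over to the hydroxy compounds is untested, and it rests on a single pair. Given the step seen with compound 2, a step of similar size and the same direction is expected in this assay. The estimated step is a 2.2-fold lower number from compound 3 to compound 4 (0.34 log units; beyond the scatter).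

For compound 4 the expected value is 17000 nM, with an estimated range from 8500 nM to 36000 nM.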

Compound 4, half-maximal inhibitory concentration: 20500 nM
For compound 4 the middle estimate is 1.2-fold (0.08 log units) below the measured one; measured number inside the range.
By their numbers in this assay, from the lowest: compounds 2, 4, 3 and 1 (each within the scatter of the next, the first and the last beyond it).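

For the compounds shown here, on the hydroxy core, the change from methoxycarbonyl to benzyloxycarbonyl gives a 1.8-fold lower number from compound 3 to compound 4 (0.26 log units; within the scatter), so this pair alone does not separate the two compounds, and the phenyl group no longer gives a step that clears the scatter, as it did on the chloro core. Even so, the steps on the two cores cannot be told apart, which leaves one modest effect of this change in this assay as a reading compatible with both pairs, though not one proved by them: the same change on two cores in this assay, a 2.2-fold lower number (0.35 log units; beyond the scatter) from compound 1 to compound 2 and a 1.8-fold lower number (0.26 log units; within the scatter) from compound 3 to compound 4, 1.2-fold (0.09 log units) apart, within the scatter of two such steps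

Hydroxy in place of chloro on a saturated ring carbon, so far seen only with methoxycarbonyl, now also leaves the number effectively unchanged with benzyloxycarbonyl, with a 1.1-fold higher number from compound 2 to compound 4 (0.06 log units; within the scatter), and the result at this position holds on both esters: the same change on two cores in this assay, a 1.1-fold lower number (0.03 log units; within the scatter) from compound 1 to compound 3 and a 1.1-fold higher number (0.06 log units; within the scatter) from compound 2 to compound 4, 1.2-fold (0.09 log units) apart, within the scatter of two such steps

As far as these compounds go, it remains open whether an amine on the same saturated ring carbon would also leave the number unchanged, or whether only the chloro and hydroxy groups behave this way. At the ester, a carboxylic acid or a longer chain in place of benzyloxycarbonyl could show whether the number can move further than these four compounds do.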